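Chloro to Cyano: Expecting the Next Compound's Response

A few compounds are considered here, and "the series" means these few. Any claim that something is new, unique, unknown or untested is made for them only; others in the source may bear on it.

Measured so far:
compound 1 `Cc1cc(NC(=O)Cn2nnc(-c3ccccc3)n2)n(C2CCC(F)(F)CC2)n1`: 68%
compound 3 `Cc1cc(NC(=O)Cn2nnc(-c3cccc(Cl)c3)n2)n(C2CCCCC2)n1`: 89%
compound 2 `CC1(c2cc(NC(=O)Cn3nnc(-c4ccccc4)n3)n(C3CCCCC3)n2)CC1`: a limit only, > 10%

All three compounds were tested in an assay on HEK293 cells for activation of Kir3.1/Kir3.2 (Homo sapiens), read by thallium flux; on this read-out higher numbers stand for larger maximal responses and lower numbers for smaller maximal responses. Compound 3 gives 89%, the highest of the two numbers measured. Its nearest neighbour is compound 1, which gives 68%, a value that sits beyond the usual scatter below it. For compound 2 the assay reports only a limit, > 10%, and not a number (the limit of > 10% in this assay, at which 1 of the 3 values shown sits).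

Compound 4 `Cc1cc(NC(=O)Cn2nnc(-c3cccc(C#N)c3)n2)n(C2CCCCC2)n1` has not yet been measured. It differs from compound 3 in a single place: cyano in place of chloro on an aromatic carbon. Among the measured compounds shown here, no pair of measured compounds shows this exact change, so its size cannot be read off from the data and can only be expected. A small downward step, within or just beyond the scatter, is expected a number 14 percentage points lower from compound 3 to compound 4 (beyond the scatter). Compound 4 is therefore estimated to reach 75% in this assay, with a range from 50% to 95%.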

Compound 4, largest response reached (Emax), in percent of the reference or control that the assay uses: 80%
Compound 4: the middle estimate sits 5 percentage points below what was measured; the measured number falls inside the stated range.
By their numbers in this assay, from the lowest: compound 1; then compounds 4 and 3 (each within the scatter of the next).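

Cyano in place of chloro gives a number 9 percentage points lower from compound 3 to compound 4 (within the scatter) in this assay, so on this read-out the two compounds cannot be told apart. This is the first pair shown that differs in one place, and it shows that on this aromatic carbon, meta to a large group, 3-chlorophenyl can give way to 3-cyanophenyl, which brings in a hydrogen-bond acceptor and a triple bond, without a step beyond the scatter. The data shown offer no measured explanation for this outcome.

What the compounds shown leave open is whether an amine or a carboxylic acid at this same place would also keep the response. As far as these compounds go, it also remains open whether the same change from chloro to cyano would give a similar step alongside the difluorinated ring of compound 1.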